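Swapping fluoro for methyl on the shared core

A few compounds are considered here, and "the series" means these few. Any claim that something is new, unique, unknown or untested is made for them only; others in the source may bear on it.

In a functional assay on SW-620 cells (Homo sapiens) for antiproliferative activity, read by sulforhodamine B assay, with a stated time of 48 h (a higher number here means a weaker inhibitor, a lower number a stronger inhibitor), compound 1 `O=C(CCCCCCN1C(=O)/C(=N\O)c2ccccc21)NO` gives 640 nM and compound 2 `O=C(CCCCCCN1C(=O)/C(=N\O)c2cc([N+](=O)[O-])ccc21)NO` gives 3390 nM as its half-maximal inhibitory concentration. Compound 3 `CO/N=C1/C(=O)N(CCCCCCC(=O)NO)c2ccc(F)cc21` gives 1110 nM in the same test. That number lies within the usual scatter of compound 1 and is clearly lower than that of compound 2, so compound 3 sits close to the better of the two earlier compounds.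

Compound 4 `CO/N=C1/C(=O)N(CCCCCCC(=O)NO)c2ccc(C)cc21` has not been measured yet. It differs from compound 3 by a single swap, (methyl in place of fluoro on an aromatic carbon), in which methyl takes the place of fluoro on an aromatic carbon.

Within the data shown here, no measured step makes this exact swap. The nearest guide is a 5.3-fold higher number from compound 1 to compound 2 (0.72 log units; beyond the scatter), where nitro replaces hydrogen on an aromatic carbon. That step goes beyond the scatter and shows that the number can respond to a group placed on an aromatic carbon. However, it involves different groups, so its size cannot simply be carried over.

With so little direct evidence, the expected step in this assay is none beyond the scatter, estimated as a 1.1-fold higher number from compound 3 to compound 4 (0.03 log units; within the scatter) here. For compound 4 the estimated value is 1200 nM, with an expected range from 450 nM to 3000 nM.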

Compound 4, half-maximal inhibitory concentration: 1070 nM
The estimate for compound 4 lay 1.1-fold (0.05 log units) above the measured number; measured number inside the range.
By their numbers in this assay, from the lowest: compounds 1, 4 and 3 (each within the scatter of the next); then compound 2.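

In this assay the exchange of fluoro for methyl on this aromatic carbon gives a 1.0-fold lower number from compound 3 to compound 4 (0.02 log units; within the scatter) and so lies within the scatter, which means the assay does not separate these two groups at this place on the shared core. Among these compounds, until now the only step on an aromatic carbon was the nitro exchange, a 5.3-fold higher number from compound 1 to compound 2 (0.72 log units; beyond the scatter) and beyond the scatter, so this result adds that not every exchange on such a carbon moves the number clearly, although the two steps involve different groups and different compounds. No measurement shown here bears on why methyl and fluoro give such similar numbers.

As far as these compounds go, whether this place also accepts groups of a different kind remains open, for example an amine, a carboxylic acid or a methoxy group on the same aromatic carbon. From the compounds shown here alone, it is equally open whether methyl and fluoro would still match on the core of compound 1, or with a longer chain leading to the hydroxamic acid end.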